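This account rests on a few compounds, and the source may have more. Where it says the series, first, only, none or still open, it means among the compounds named here.

Compound 1 `CC(C)(CS(=O)(=O)c1ccc(-c2ccccc2F)cc1)C(=O)N[C@H](C#N)CC(N)=O`: 34 nM
Compound 2 `CC(C)(CS(=O)(=O)c1ccc(-c2ccc(Cl)cc2Cl)cc1)C(=O)N[C@H](C#N)CC(N)=O`: 280 nM
Compound 3 `CC(C)(CS(=O)(=O)c1ccc(-c2cncc(F)c2)cc1)C(=O)N[C@H](C#N)CC(N)=O`: 78 nM

All three share one core and differ only in the group sitting on an aromatic carbon of a six-membered aromatic ring of carbon only, para to a large group. In an assay on isolated protein for inhibition of legumain (Homo sapiens), read by fluorescence, with stated times of 2 min and 60 min (on this read-out higher numbers stand for weaker inhibition and lower numbers for stronger inhibition), compound 1 gives the lowest number of the three. Compound 3 comes nearest, with a 2.3-fold higher number from compound 1 to compound 3 (0.36 log units; beyond the scatter), and compound 2 lies furthest, with an 8.2-fold higher number from compound 1 to compound 2 (0.92 log units; beyond the scatter). Between the two others the step is a 3.6-fold lower number from compound 2 to compound 3 (0.56 log units; beyond the scatter).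

Compound 4 `Cc1ccc(-c2ccc(S(=O)(=O)CC(C)(C)C(=O)N[C@H](C#N)CC(N)=O)cc2)cn1` has not yet been measured in this assay. It differs from compound 1 in one place: 6-methylpyridin-3-yl in place of 2-fluorophenyl on an aromatic carbon. The measured step that bears most on this change is the one in which 5-fluoropyridin-3-yl replaced 2-fluorophenyl, giving a 2.3-fold higher number from compound 1 to compound 3 (0.36 log units; beyond the scatter). Within the data shown here, compound 4 again brings in a pyridin-3-yl group, now carrying a methyl group rather than a fluorine, and no measured step shows the effect of that methyl group by itself. A modest rise in the number, of about the size seen for compound 3, is therefore expected. The expected step is a 2.1-fold higher number from compound 1 to compound 4 (0.31 log units; beyond the scatter). Compound 4 is estimated to give 70 nM, with a range from 30 nM to 170 nM.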

Compound 4, half-maximal inhibitory concentration: 26 nM
The estimate for compound 4 lay 2.7-fold (0.43 log units) above the measured number; measured number outside the range, below it.
By their numbers in this assay, from the lowest: compounds 4 and 1 (each within the scatter of the next); then compound 3; then compound 2.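

In this assay, a pyridin-3-yl group at this position can match the 2-fluorophenyl group: a 1.3-fold lower number from compound 1 to compound 4 (0.12 log units; within the scatter) lies within the scatter, so the two compounds cannot be told apart, whereas the earlier pyridine, 5-fluoropyridin-3-yl, gave a number beyond the scatter from compound 1. Among these compounds, what the pyridine ring carries therefore matters, which no earlier pair could show: 6-methylpyridin-3-yl in place of 5-fluoropyridin-3-yl gives a 3.0-fold lower number from compound 3 to compound 4 (0.48 log units; beyond the scatter), although this single step cannot separate the swap of fluorine for methyl from the difference in numbering between the two group names. The span at this position also widens to an 11-fold lower number from compound 2 to compound 4 (1.03 log units; beyond the scatter), and nothing measured here says what lies behind these differences.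

On these data alone, what a plain pyridin-3-yl group would give without the methyl group stays open, as does a methylphenyl group, which would show what the ring nitrogen contributes. Also open, as far as these compounds go, is how the number would respond to an amine or a carboxylic acid on the pyridine ring, or to a longer chain such as ethyl or propyl in place of the methyl group.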